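Chlorophenyl Sulfonamide After Three Limits

The source may hold more compounds than are shown below. What is called first, only, known or untested is meant among the compounds shown, and "the series" means these compounds.

Three sulfonamides on a shared core were tested in an assay on isolated protein for inhibition of malate dehydrogenase, mitochondrial (Sus scrofa), with stated times of 45 min and 30 min; a lower number here means a stronger inhibitor, a higher number a weaker inhibitor. Compound 1 `O=S(=O)(Nc1ccc(-c2nc3ccccc3o2)cc1)c1ccc(Cl)c(C(F)(F)F)c1` gives only a limit of the assay, > 63000 nM. Compound 2 `Cc1ccc(S(=O)(=O)Nc2ccc(-c3nc4ccccc4o3)cc2)cc1` likewise gives only a limit, > 63000 nM. Compound 3 `COc1ccccc1S(=O)(=O)Nc1ccc(-c2nc3ccccc3o2)cc1` also reaches only a limit, > 63000 nM. Within the data shown here, the single step among them, a step that the two limits leave unreadable from compound 2 to compound 3, cannot be read, both of its ends being limits; the limit of > 63000 nM in this assay, at which 3 of the 3 values shown sit, shows every value of the set sitting at that same limit. Compound 3 therefore stands at the limit and nowhere else: no number places it. Compound 4 `O=S(=O)(Nc1ccc(-c2nc3ccccc3o2)cc1)c1ccc(Cl)cc1` differs from compound 3 by 4-chlorophenyl in place of 2-methoxyphenyl on a sulfonyl sulfur. Among the measured compounds shown here, no readable measured step bears on this change, and nothing among the measured compounds points to any inhibition at all. Compound 4 is accordingly expected to remain at the limit, estimated at 100000 nM with a range from 40000 nM to 300000 nM. The step this estimate implies, a step that the limit leaves unreadable from compound 3 to compound 4, is expected to be none beyond the scatter.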

Compound 4, half-maximal inhibitory concentration: > 63000 nM
Compound 4 was reported as a limit (the forecaster's own chance of this, stated with the estimate: 90%); the middle value is on the limit's open side.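

None of the new steps from compound 1, compound 2 or compound 3 to compound 4 can be read in this assay, both ends of each being limits: the limit of > 63000 nM in this assay, at which 4 of the 4 values shown sit. The compounds shown leave open whether any group on the sulfonyl sulfur of the shared core gives measurable inhibition.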